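Ethoxy to Methoxymethyl: What to Expect for Compound 3

The source may report more compounds than this note shows. Statements on the series, on what has been measured and on what is new or still open speak of the compounds shown alone.

Compound 1, `O=S(=O)(CCO)c1ccc(COC[C@@H]2C[C@@H]2C2CCN(c3ncc(Cl)cn3)CC2)c(F)c1`: 2.3 nM in a functional assay on CHO cells for agonist activity at Glucose-dependent insulinotropic receptor (Homo sapiens), read by cAMP accumulation; a lower number here means that less compound is needed, a higher number that more compound is needed for the effect
Compound 2, `CCOc1cnc(N2CCC([C@H]3C[C@H]3COCc3ccc(S(C)(=O)=O)c(F)c3)CC2)nc1`: 1.7 nM in this assay

Both measured compounds share a core, and both act in this assay at low concentrations. Compound 2 gives the lower of the two numbers, but its gap to compound 1 is within the scatter of repeated measurements, so the two cannot be placed in any order on these data.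

Compound 3, `COCc1cnc(N2CCC([C@H]3C[C@H]3COCc3ccc(S(C)(=O)=O)c(F)c3)CC2)nc1`, has not been measured. It differs from compound 2 in one place: methoxymethyl in place of ethoxy on an aromatic carbon. The two compounds contain the same atoms, joined differently.

For the measured compounds named here, no measured pair shows this exchange, so there is no step to lean on. Both groups are small, uncharged and carry one acceptor, and the change is at the far end of the molecule from the sulfone. The expectation is a step from compound 2 to compound 3 of a 1.5-fold higher number from compound 2 to compound 3 (0.17 log units; within the scatter), that is, nothing beyond the scatter in either direction. Compound 3 is therefore estimated to give 2.5 nM in this assay, within a range from 0.8 nM to 8 nM.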

Compound 3, half-maximal effective concentration: 3.3 nM
The estimate for compound 3 lay 1.3-fold (0.12 log units) below the measured number, and the stated range covers the measured number.
By their numbers in this assay, from the lowest: compounds 2, 1 and 3 (each within the scatter of the next).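

In this assay the exchange of ethoxy for methoxymethyl gives a 1.9-fold higher number from compound 2 to compound 3 (0.29 log units; within the scatter) and so counts as no measurable change: the same atoms, joined differently on an aromatic carbon para to a large group, give a result that cannot be told apart from repeat-to-repeat variation. For the compounds shown here, this is the first measured step at this position, and it shows that the two groups can be exchanged here with compound 3 still acting at low concentrations, although a single pair cannot show how far that holds for other groups. Nothing available explains this result, so it stands as an observation without a known cause.

The compounds shown leave open whether the position would accept groups of a different kind, such as an amine or a carboxylic acid, or a longer chain such as butoxy, as readily as these two uncharged, ring-free groups of equal size. Also open, from the compounds shown here alone, is whether the same exchange would give a similar step on a molecule with a different sulfone side chain, such as the hydroxyethyl sulfone of compound 1.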